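Isopropyl on compound 1: working notes

This account rests on a few compounds, and the source may have more. Where it says the series, first, only, none or still open, it means among the compounds named here.

Measured in a functional assay (thoracic aorta) for inhibition, with Rattus norvegicus as the target; on this read-out lower numbers stand for stronger inhibition and higher numbers for weaker inhibition:
- compound 1 `O=C(O)c1cc(CCCCCCNS(=O)(=O)c2ccccc2)c2cccccc1-2`: 140 nM
- compound 2 `COc1ccc(S(=O)(=O)NCCCCc2cc(C(=O)O)c3ccc(C(C)C)ccc2-3)cc1`: 160 nM
- compound 3 `CC(C)c1cccc2c(CCCNS(=O)(=O)c3ccccc3)cc(C(=O)O)c-2c1`: 7400 nM

Compound 1 stands at the low end of these numbers, level with compound 2 within the scatter, while compound 3 lies far higher, well beyond the scatter. The next compound to be read is compound 4 `CC(C)c1cccc2c(CCCCCCNS(=O)(=O)c3ccccc3)cc(C(=O)O)c-2c1`, which departs from compound 1 by isopropyl in place of hydrogen on an aromatic carbon. Among the measured compounds shown here, no pair of measured compounds isolates this change in this assay. Isopropyl is present in compound 2 at 160 nM and also in compound 3 at 7400 nM, so these two values give no single direction for the group. No step beyond the scatter is expected, and the expected step is a 1.2-fold lower number from compound 1 to compound 4 (0.07 log units; within the scatter). The range is kept wide, especially towards higher numbers, given compound 3 at 7400 nM. The estimated value for compound 4 is 120 nM, with an expected range from 30 nM to 600 nM.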

Compound 4, half-maximal inhibitory concentration: 920 nM
For compound 4 the middle estimate is 7.7-fold (0.88 log units) below the measured one, and the stated range ends below it.
By their numbers in this assay, from the lowest: compounds 1 and 2 (each within the scatter of the next); then compound 4; then compound 3.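

In this assay, isopropyl in place of hydrogen on an aromatic carbon of the seven-membered aromatic ring gives a 6.6-fold higher number from compound 1 to compound 4 (0.82 log units; beyond the scatter) and so has a direction of its own on this chain: weaker inhibition. Among the compounds shown here, compound 2 and compound 3 carry isopropyl but differ from compound 1 in other places as well, so only this pair isolates the group. Compound 4 differs from compound 3 in the chain, and compound 3 still prints the higher number at 7400 nM in this series. Nothing in hand gives a measured reason for the step.

Open, as far as these compounds go, is whether methyl, chlorine or methoxy on the same carbon would cost as much as isopropyl. Also open, from the compounds shown here alone, is how isopropyl compares with hydrogen on the chain of compound 3, which has no partner without the group.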